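Removing One Methoxy Group in Two Matched Pairs

The source may report more compounds than this note shows. Statements on the series, on what has been measured and on what is new or still open speak of the compounds shown alone.

Compound 1 `COc1cc(/C=C/C(=O)c2ccccc2F)cc(OC)c1OC` and compound 2 `COc1cc(/C=C/C(=O)c2ccccc2F)cc(OC)c1` were both tested in a functional assay on HCT-15 cells (Homo sapiens) for cytotoxicity, read by MTT assay, with a stated time of 72 h; on this read-out higher numbers stand for weaker inhibition and lower numbers for stronger inhibition. Compound 1 gives 134 nM, while compound 2 gives 20.9 nM, a step of a 6.4-fold lower number from compound 1 to compound 2 (0.81 log units; beyond the scatter); the change is hydrogen in place of methoxy on an aromatic carbon. Compound 3 `COc1ccc(C(=O)/C=C/c2ccc(OC)c(OC)c2OC)c(F)c1` gives 31.7 nM in this assay. Its core differs from that of compound 1 in more than one place, and that difference is not broken down here. Compound 4 `COc1ccc(C(=O)/C=C/c2ccc(OC)cc2OC)c(F)c1` has not yet been measured; it arises from compound 3 by hydrogen in place of methoxy on an aromatic carbon, the same kind of change as in the first pair, but here the carbon is meta to a large group rather than para to a large group. The earlier step of a 6.4-fold lower number from compound 1 to compound 2 (0.81 log units; beyond the scatter) lay well beyond the scatter. On that basis, for compound 4 a step of about a 4.0-fold lower number from compound 3 to compound 4 (0.60 log units; beyond the scatter) is expected, though the different placement leaves it less certain. Compound 4 is expected to give 8 nM in this assay, plausibly between 3 nM and 25 nM.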

Compound 4, half-maximal inhibitory concentration: 72.2 nM
Beside the measured number, compound 4's estimate is 9.0-fold (0.96 log units) below it, outside the stated range (above it).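

In this assay, the second removal of a methoxy group gives a 2.3-fold higher number from compound 3 to compound 4 (0.36 log units; beyond the scatter), which does not repeat the direction of a 6.4-fold lower number from compound 1 to compound 2 (0.81 log units; beyond the scatter). The same change thus moves the number in opposite directions on the two cores, and the two steps differ clearly: the same change on two cores in this assay, a 6.4-fold lower number (0.81 log units; beyond the scatter) from compound 1 to compound 2 and a 2.3-fold higher number (0.36 log units; beyond the scatter) from compound 3 to compound 4, 15-fold (1.16 log units) apart, beyond the scatter of two such steps. This shows that the result of putting hydrogen in place of methoxy does not carry over from the core of compound 1 to the core of compound 3, but two pairs that differ both in the core and in the placement of the change cannot show which of these matters.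

The compounds shown leave open what an amine or a hydroxyl group on that aromatic carbon would give in this assay. They also leave open whether either direction would hold on a third core.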